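The source may hold more compounds than are shown below. What is called first, only, known or untested is meant among the compounds shown, and "the series" means these compounds.

Compound 3 `O=C(O)CS(=O)(=O)c1ccc(OCc2cccc(-c3ccccc3F)c2)cc1` carries a fluoro group on the outer ring, and in a physicochemical assay for lipophilicity, using the shake flask method, in phosphate buffer, measured as octanol-water partition, with a stated time of 24 h, at pH 7.4, tested at 100 uM (on this read-out lower numbers stand for lower lipophilicity and higher numbers for higher lipophilicity), the outcome for compound 3 reads "not determined" (no result reported), so it stands nowhere on the measured scale. Compound 4 `CC(C)c1ccccc1-c1cccc(COc2ccc(S(=O)(=O)CC(=O)O)cc2)c1` differs from it at one position: isopropyl in place of fluoro on an aromatic carbon. Among the measured compounds, compound 1 `COc1cc(C)c(-c2cccc(COc3ccc(S(=O)(=O)CC(=O)O)cc3)c2)c(C)c1` gives 2.45 and compound 2 `Cc1ccccc1-c1cccc(COc2ccc(S(=O)(=O)CC(=O)O)cc2)c1` gives 2.35 in this assay, and the only measured step, a number 0.10 log units lower from compound 1 to compound 2 (within the scatter), concerns a different exchange on that ring. Going by the values given here, no measured step traces the change from compound 3 to compound 4, so compound 2 serves as the nearest reference point. Compound 4 is expected to lie clearly above compound 2, beyond the scatter, at an estimated 3.1 with a range from 2.6 to 3.6.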

Compound 4, distribution coefficient: 3.18
Beside the measured number, compound 4's estimate is 0.08 log units below it; low and high end bracket the measured number.
By their numbers in this assay, from the lowest: compounds 2 and 1 (each within the scatter of the next); then compound 4.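

Isopropyl in place of methyl on an aromatic carbon gives a number 0.83 log units higher from compound 2 to compound 4 (beyond the scatter) in this assay, so this position on the outer ring can move the read-out beyond the scatter. The exchange of 4-methoxy-2,6-dimethylphenyl for 2-isopropylphenyl gives a number 0.73 log units higher from compound 1 to compound 4 (beyond the scatter), which sets compound 4 apart from two compounds that lie within the scatter of each other. Nothing shown here accounts for the rise.

The step from fluoro to isopropyl cannot be read, as compound 3 has no number. On these data alone, whether an amine or a longer chain at this position would shift the read-out in the same direction remains open.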